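The compounds below may be only part of what the source reports. "The series", "measured", "known", "first", "only" and "open" are said of these compounds alone.

Within the data shown here, in a functional assay on B16 cells (Mus musculus) for inhibition (on this read-out lower numbers stand for stronger inhibition and higher numbers for weaker inhibition), compound 2 (`COc1cc(/C=C/C(=O)c2cccc(N)c2)ccc1O`) gives 11.5 ug/mL and holds the higher of the two numbers so far, while compound 1 (`COc1cc(/C=C/C(=O)c2cccc(NC(=O)c3ccc(Cl)cc3)c2)ccc1O`) gives 0.59 ug/mL on this read-out. Compound 3 (`COc1cc(/C=C/C(=O)c2cccc(NC(=O)c3ccc(Cl)c(Cl)c3)c2)ccc1O`) differs from compound 2 by one change ((3,4-dichlorophenyl)carbonyl in place of hydrogen on a nitrogen on an aromatic ring), namely (3,4-dichlorophenyl)carbonyl in place of hydrogen on a nitrogen on an aromatic ring. Among the measured compounds shown here, the one measured step that bears on this, a 19-fold higher number from compound 1 to compound 2 (1.29 log units; beyond the scatter) with hydrogen in place of (4-chlorophenyl)carbonyl on that same nitrogen, is large and beyond the scatter, so a large move to a lower number is expected for compound 3, which carries a closely related group. For the measured compounds named here, no measured pair shows what the second chlorine adds. The expected step is a 23-fold lower number from compound 2 to compound 3 (1.36 log units; beyond the scatter) in size, close to the reverse of the measured one. For compound 3 the estimated value is 0.5 ug/mL within an expected range of 0.15 ug/mL to 1.6 ug/mL on repeat measurement.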

Compound 3, half-maximal inhibitory concentration: 3.88 ug/mL
The estimate for compound 3 lay 7.8-fold (0.89 log units) below the measured number; measured number above the stated range.
By their numbers in this assay, from the lowest: compound 1; then compound 3; then compound 2.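

In this assay, (3,4-dichlorophenyl)carbonyl on the nitrogen gives a 3.0-fold lower number from compound 2 to compound 3 (0.47 log units; beyond the scatter), so this acyl group still improves on the free amine, though by less than (4-chlorophenyl)carbonyl does. Among these compounds, the added chlorine is the first change measured on the acyl group's own ring, and it gives a 6.6-fold higher number from compound 1 to compound 3 (0.82 log units; beyond the scatter), so the two acyl groups are not interchangeable at this nitrogen and a single chloro in place of hydrogen on that ring moves the number beyond the scatter. Nothing at hand accounts for the loss that comes with the added chlorine.

As far as these compounds go, whether that loss is specific to chlorine stays open, since a fluoro or a methoxy group at the same carbon could behave differently. Also open, from the compounds shown here alone, is whether the carbonyl link matters, which a sulfonamide or a benzyl group on the same nitrogen would test.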